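This account rests on a few compounds, and the source may have more. Where it says the series, first, only, none or still open, it means among the compounds named here.

Of the compounds shown here, three have been measured so far in a functional assay on the whole organism (artery, strain albino) with Rattus norvegicus as the target, with a stated time of 360 min, at a dose of 10 mg/kg by the oral route; on this read-out lower numbers stand for less inhibition and higher numbers for more inhibition at the one dose given (going by the name of the read-out). Compound 1 `CC1=C(C(=O)Nc2ccc([N+](=O)[O-])cc2)C(c2ccc(Br)cc2)N=C(SCc2ccc(Cl)cc2)N1` gives 39.2%. Compound 2 `CC1=C(C(=O)Nc2ccc([N+](=O)[O-])cc2)C(c2cccc([N+](=O)[O-])c2)N=C(SCc2ccccc2)N1` gives 32.5%, and compound 3 `CC1=C(C(=O)Nc2ccc([N+](=O)[O-])cc2)C(c2cccc([N+](=O)[O-])c2)N=C(SCc2cccc(Cl)c2)N1` gives 21.6%, the lowest of the three numbers, with compound 2 nearest to it and compound 1 furthest away. For the measured compounds named here, the only pair that differs in one place runs a number 10.9 percentage points lower from compound 2 to compound 3 (beyond the scatter).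

Compound 4 `CC1=C(C(=O)Nc2ccc([N+](=O)[O-])cc2)C(c2cccc([N+](=O)[O-])c2)N=C(SCc2ccc(Cl)cc2)N1` has not yet been measured. It differs from compound 3 in 4-chlorophenyl in place of 3-chlorophenyl on a saturated chain carbon bound to a sulfur. Going by the values given here, no measured step shifts the chlorine in this way. Among the compounds with values here, compound 1 carries the same (4-chlorobenzyl)sulfanyl group as compound 4 but also differs from it on the other aromatic ring, so its value shows only that this group can sit alongside the higher numbers seen here. Because a number 10.9 percentage points lower from compound 2 to compound 3 (beyond the scatter) was modest, the step from a hydrogen to a chlorine changed the read-out only a little, and shifting that chlorine is expected to do no more. Compound 4 is therefore expected to give about 30%, within 18% to 42%. That estimate means a step of a number 8.4 percentage points higher from compound 3 to compound 4 (within the scatter).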

Compound 4, a percentage reported as inhibition, in the whole organism at one dose (the size of the read-out at that dose, not a potency): 33%
Compound 4: the middle estimate sits 3 percentage points below what was measured; the measured number falls inside the stated range.
By their numbers in this assay, from the lowest: compound 3; then compounds 2, 4 and 1 (each within the scatter of the next).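

In this assay the place of the chlorine counts, not only its presence: 4-chlorophenyl in place of 3-chlorophenyl on the saturated chain carbon bound to a sulfur gives a number 11.4 percentage points higher from compound 3 to compound 4 (beyond the scatter) and is a step beyond the scatter. Chloro in place of hydrogen on this ring gives a number 0.5 percentage points higher from compound 2 to compound 4 (within the scatter) here, so adding a chlorine at this other place leaves the number within the scatter, unlike the step to compound 3. With the 4-chlorobenzyl group held constant, 3-nitrophenyl in place of 4-bromophenyl on the saturated ring carbon gives a number 6.2 percentage points lower from compound 1 to compound 4 (within the scatter) and also stays within the scatter.

Nothing available here gives a reason for these numbers. Whether a methoxy group or an amine in place of the chlorine would behave like either chlorine remains open, as does how any of these compounds behaves at other doses.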